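A few compounds are considered here, and "the series" means these few. Any claim that something is new, unique, unknown or untested is made for them only; others in the source may bear on it.

Working notes on the series. Three compounds have numbers in an assay on isolated protein for binding affinity to Equilibrative nucleoside transporter 1 (Homo sapiens); a higher number here means a weaker inhibitor, a lower number a stronger inhibitor. Compound 1, `O=[N+]([O-])c1cccc2c1CCN(c1ncnc3c1ncn3[C@@H]1O[C@H](CO)[C@@H](O)[C@H]1O)C2`, gives 3020 nM in this assay. Compound 2, `OC[C@H]1O[C@@H](n2cnc3c(NCc4ccco4)ncnc32)[C@H](O)[C@@H]1O`, gives 36300 nM in this assay. Compound 3, `CCCSc1nc(N)nc2c1ncn2CC(C)C`, gives 63100 nM in this assay. Compound 2 stands second highest of the three numbers; the gap to compound 3 is within the scatter, so no order between compound 2 and compound 3 is claimed, while compound 1 gives a number beyond the scatter below that of compound 2.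

The step to be followed goes from compound 2 to compound 4, `OC[C@H]1O[C@@H](n2cnc3c(CSc4ccccc4Br)ncnc32)[C@H](O)[C@@H]1O`, not yet measured in this assay. The change is ((2-bromophenyl)sulfanyl)methyl in place of ((furan-2-yl)methyl)amino on an aromatic carbon. Going by the values given here, no step between two measured compounds is known for this series, so the size of this step has no precedent here. The change removes the one hydrogen-bond donor and puts a larger group, with one six-membered aromatic ring of carbon only and a bromine, on the aromatic carbon of the shared core.

Given the spread of the three measured numbers, a step down from compound 2 is expected for compound 4, of the size a 3.0-fold lower number from compound 2 to compound 4 (0.48 log units; beyond the scatter), though a result within the scatter would not be surprising. Compound 4 is estimated at 12000 nM in this assay, with a range from 2500 nM to 60000 nM.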

Compound 4, half-maximal inhibitory concentration: 2400 nM
Estimate against measurement, compound 4: 5.0-fold (0.70 log units) above; measured number outside the range, below it.
By their numbers in this assay, from the lowest: compounds 4 and 1 (each within the scatter of the next); then compounds 2 and 3 (each within the scatter of the next).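

In this assay, going by these compounds alone, ((2-bromophenyl)sulfanyl)methyl in place of ((furan-2-yl)methyl)amino on the aromatic carbon of the shared core gives a 15-fold lower number from compound 2 to compound 4 (1.18 log units; beyond the scatter), the first step that can be read, and it shows that the number responds strongly to the group at this position while the rest of the molecule stays the same. The entering group has no hydrogen-bond donor, yet compound 4 gives the lower number of the pair, so a donor in this group is not needed to reach the level at which compound 4 at 2400 nM and compound 1 at 3020 nM lie within the scatter of each other. The step changes the aromatic ring, the link to the core, the bromine and the donor count all at once, and no measurement at hand ties the change in number to any one of them.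

Still open, going by these compounds, is which part of the entering group carries the step: the bromine, the sulfur link or the carbon-only ring. A phenylsulfanylmethyl group without bromine, a chlorine in place of the bromine, or a benzylamino group on the same carbon would begin to separate these parts.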